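This account rests on a few compounds, and the source may have more. Where it says the series, first, only, none or still open, it means among the compounds named here.

Measured compounds in a functional assay on SW480 cells (Homo sapiens) for cytotoxicity, read by MTT assay, with a stated time of 4 days; on this read-out lower numbers stand for stronger inhibition and higher numbers for weaker inhibition:
Compound 1 `C=C1C[C@]23C[C@@]1(O)CC[C@@H]2c1cccc(C)c1[C@@H]3Cn1cc(-c2ccc(Cl)cc2)nn1` gives > 20000 nM, a limit of the assay.
Compound 2 `C=C1C[C@]23C[C@@]1(O)CC[C@@H]2c1cccc(C)c1[C@@H]3Cn1cc(-c2ccc(Br)cc2)nn1` gives > 20000 nM, a limit of the assay.

Compound 2 thus stands only at a limit in this assay, as do all values shown: the limit of > 20000 nM in this assay, at which 2 of the 2 values shown sit. The step that the two limits leave unreadable from compound 1 to compound 2 cannot be read for that reason. Compound 3 `C=C1C[C@]23C[C@@]1(O)CC[C@@H]2c1cccc(C)c1[C@@H]3Cn1cc(-c2ccccn2)nn1` differs from compound 2 by pyridin-2-yl in place of 4-bromophenyl on an aromatic carbon. Among the measured compounds shown here, no measured step bears on this change, and the two limits give no direction, so compound 3 is expected to stay near the limit. Compound 3 is estimated at 25000 nM, between 8000 nM and 80000 nM. The step that the limit leaves unreadable from compound 2 to compound 3 is expected to be none beyond the scatter.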

Compound 3, half-maximal inhibitory concentration: > 20000 nM
Compound 3: only a limit was reported (the forecaster's own chance of this, stated with the estimate: 70%); the middle value does not contradict the limit.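

Compound 1, compound 2 and compound 3 all stand only at a limit in this assay, so no step among them can be read: the limit of > 20000 nM in this assay, at which 3 of the 3 values shown sit.

The compounds shown leave open whether any of these aryl groups changes the read-out at all.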